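The compounds below may be only part of what the source reports. "The series", "measured", "known", "first", "only" and "open" are said of these compounds alone.

Compound 1, `C[C@H](NC(=O)c1c(C2CC2)nnn1Cc1ccc(C(F)(F)F)cc1)c1ccc(C(=O)O)cc1`: in a functional assay on CHO cells for antagonist activity at prostaglandin E2 receptor EP4 subtype (Homo sapiens), read by calcium flux, with a stated time of 15 min (on this read-out higher numbers stand for weaker inhibition and lower numbers for stronger inhibition), compound 1 gives 52.1 nM.
Compound 2, `C[C@H](NC(=O)c1c(C2CCC2)nnn1Cc1ccc(C(F)(F)F)cc1)c1ccc(C(=O)O)cc1`: in this assay compound 2 gives 75.3 nM.

Within the data shown here, compound 2 stands beside compound 1, the only other measured compound. Among the measured compounds shown here, the one step that connects them, a 1.4-fold higher number from compound 1 to compound 2 (0.16 log units; within the scatter), lies within the scatter, so on these numbers the two compounds cannot be told apart.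

Compound 3, `C[C@H](NC(=O)c1c(C2CCCCC2)nnn1Cc1ccc(C(F)(F)F)cc1)c1ccc(C(=O)O)cc1`, has not been measured in this assay. It differs from compound 2 in one place: cyclohexyl in place of cyclobutyl on an aromatic carbon. For the measured compounds named here, the only measured step that touches this position is a 1.4-fold higher number from compound 1 to compound 2 (0.16 log units; within the scatter), which enlarged the ring by one carbon and stayed within the scatter. Going by the values given here, the change to compound 3 enlarges the ring further, by two carbons, and no measured compound shows what a ring of that size does at this position. On this basis the expected step of a 1.5-fold higher number from compound 2 to compound 3 (0.16 log units; within the scatter) is small, if anything toward a higher number, with wide uncertainty. Compound 3 is therefore estimated at 110 nM in this assay, within a range of 40 nM to 350 nM.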

Compound 3, half-maximal inhibitory concentration: 161 nM
Estimate against measurement, compound 3: 1.5-fold (0.17 log units) below; low and high end bracket the measured number.
By their numbers in this assay, from the lowest: compounds 1 and 2 (each within the scatter of the next); then compound 3.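

In this assay, among these compounds, cyclohexyl on this aromatic carbon produces the first changes at this position that lie beyond the scatter: a 2.1-fold higher number from compound 2 to compound 3 (0.33 log units; beyond the scatter), and a 3.1-fold higher number from compound 1 to compound 3 (0.49 log units; beyond the scatter). The position therefore does respond to the identity of the carbocycle, which the cyclopropyl and cyclobutyl compounds could not show because they cannot be told apart. The change is nevertheless only modest, so the six-membered ring of carbon is accepted here at a moderate cost in inhibition, and nothing among the data shown accounts for that cost.

The compounds shown leave open whether cyclopentyl would stay with the two smaller rings or move toward cyclohexyl, and so whether the rise in the number sets in gradually or only at the largest ring. They also leave open whether the same cost would appear with an open chain such as isopropyl or tert-butyl, or with a ring carrying a heteroatom such as tetrahydropyranyl or piperidinyl, and whether any of these would match compound 1 or compound 2 in this assay.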